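Swapping the Aryl Group on a Shared Core

This account rests on a few compounds, and the source may have more. Where it says the series, first, only, none or still open, it means among the compounds named here.

Of the compounds shown here, three built on one shared core have been tested in an ADME assay on HEL cells (Homo sapiens) for cytotoxicity, with a stated time of 3 days; on this read-out lower numbers stand for higher toxicity in this test and higher numbers for lower toxicity in this test. Compound 1 `COc1cccc(-c2cc(C)c3ncc(CSCCc4ccccc4)n3c2)c1` gives 36 ug/mL, compound 2 `Cc1cc(-c2cccc([N+](=O)[O-])c2)cn2c(CSCCc3ccccc3)cnc12` gives 43 ug/mL, and compound 3 `Cc1cc(-c2ccc(C#N)cc2)cn2c(CSCCc3ccccc3)cnc12` gives 10.6 ug/mL, the lowest number of the three. The aryl swaps a 3.4-fold lower number from compound 1 to compound 3 (0.53 log units; beyond the scatter) and a 4.1-fold lower number from compound 2 to compound 3 (0.61 log units; beyond the scatter) both moved the number down, while a 1.2-fold higher number from compound 1 to compound 2 (0.08 log units; within the scatter) did not. Compound 4 `Cc1cc(-c2ccccc2O)cn2c(CSCCc3ccccc3)cnc12` carries 2-hydroxyphenyl in place of 4-cyanophenyl on an aromatic carbon. Among the measured compounds shown here, no measured step contains this hydroxyphenyl group, so the two aryl swaps serve only as a guide to how far such a change can move the number. Compound 4 is therefore expected to move back toward the higher values, by a 2.4-fold higher number from compound 3 to compound 4 (0.37 log units; beyond the scatter), with an estimate of 25 ug/mL and a range of 8 ug/mL to 60 ug/mL.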

Compound 4, half-maximal cytotoxic concentration: > 50 ug/mL
Compound 4 was reported as a limit; the forecaster's own chance of this, stated with the estimate: 10%; at least 2.0-fold (0.30 log units) between middle value and limit.
By their numbers in this assay, from the lowest: compound 3; then compounds 1 and 2 (each within the scatter of the next). At a limit, above all of these: compound 4.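

Compound 4 is reported only as a limit in this assay: the limit of > 50 ug/mL in this assay, at which 1 of the 4 values shown sits. On this aromatic carbon of the shared core, 2-hydroxyphenyl clearly separates from 4-cyanophenyl, with an at least 4.7-fold higher number from compound 3 to compound 4 (0.67 log units; beyond the scatter). Against the other two aryl groups, the limit settles no order, with an at least 1.1-fold higher number from compound 2 to compound 4 (0.06 log units; that floor lies within the scatter) and an at least 1.3-fold higher number from compound 1 to compound 4 (0.14 log units; that floor lies within the scatter).

From the compounds shown here alone, the true number for compound 4 stays open, since only its limit is known. Also open, going by these compounds, is whether an amine or a carboxylic acid in place of the hydroxyl on this aryl ring would give a similar number.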